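The compounds below may be only part of what the source reports. "The series", "measured", "known", "first", "only" and "open" are said of these compounds alone.

Measured compounds:
Compound 1, `O=C1C[C@H](OCc2cn(C(=O)c3ccccc3)nn2)[C@H]2CO[C@@H]1O2`: 25900 nM
Compound 2, `O=C1C[C@H](OCc2cn(-c3ccccc3Br)nn2)[C@H]2CO[C@@H]1O2`: 22500 nM

Both were tested in a functional assay on MDA-MB-231 cells (Homo sapiens) for cytotoxicity, read by MTT assay, with a stated time of 48 h; on this read-out lower numbers stand for stronger inhibition and higher numbers for weaker inhibition. On these numbers compound 2 sits alongside compound 1, since a 1.2-fold lower number from compound 1 to compound 2 (0.06 log units; within the scatter) lies within the scatter. Compound 3, `O=C1C[C@H](OCc2cn(-c3cccc(Cl)c3Cl)nn2)[C@H]2CO[C@@H]1O2`, differs from compound 2 by 2,3-dichlorophenyl in place of 2-bromophenyl on an aromatic nitrogen. Among the compounds with values here, the only measured step concerns another swap on the same nitrogen and was within the scatter, so nothing measured bears directly on this change. The expected step is a 1.1-fold lower number from compound 2 to compound 3 (0.03 log units; within the scatter), nothing beyond the scatter. Compound 3 is therefore estimated at 21000 nM, with a range from 8000 nM to 55000 nM.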

Compound 3, half-maximal inhibitory concentration: 26000 nM
For compound 3 the middle estimate is 1.2-fold (0.09 log units) below the measured one; the measured number falls inside the stated range.
By their numbers in this assay, from the lowest: compounds 2, 1 and 3 (each within the scatter of the next).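

Measured in this assay the swap of the halogens on the phenyl ring gives a 1.2-fold higher number from compound 2 to compound 3 (0.06 log units; within the scatter) and the swap from benzoyl gives a 1.0-fold higher number from compound 1 to compound 3 (0.00 log units; within the scatter) on the same nitrogen. So a second halogen-bearing aryl group on this aromatic nitrogen leaves the number within the scatter, and benzoyl, 2-bromophenyl and 2,3-dichlorophenyl cannot be told apart here. No supporting evidence is available to explain this result. Still open, as far as these compounds go, is whether a phenyl ring carrying an amine or a carboxylic acid, or a longer alkyl chain, on this nitrogen would shift the number beyond the scatter.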